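The source may hold more compounds than are shown below. What is called first, only, known or untested is meant among the compounds shown, and "the series" means these compounds.

Compounds measured in a functional assay on HEK293T cells for agonist activity at histamine H2 receptor (Homo sapiens), read by beta-arrestin recruitment; a higher number here means a larger maximal response, a lower number a smaller maximal response:
- compound 1 `CCCNC(=O)/N=C(\N)NCCCc1sc(N)nc1C` gives 0.32
- compound 3 `Cc1nc(N)sc1CCCN/C(N)=N/C(=O)NCC(C)CCCc1ccccc1` gives 0.14
- compound 2 `N/C(=N\C(=O)NC1CCCCC1)Nc1cccc(-c2csc(N)n2)c1` gives "not determined" (no result reported)

Within the data shown here, compound 1 stands highest of the two numbers available; compound 3 is its nearest neighbour, and the step a number 0.18 lower from compound 1 to compound 3 (beyond the scatter) lies beyond the scatter, so this is the one measured step that bears on the series.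

Compound 4 `Cc1nc(N)sc1CCCN/C(N)=N/C(=O)NC(C)c1ccco1` is drawn from compound 1 by 1-(furan-2-yl)ethyl in place of propyl on an amide-type nitrogen. Among the measured compounds shown here, the only measured guide is the enlargement on the side chain, where the step a number 0.18 lower from compound 1 to compound 3 (beyond the scatter) was modest and downward; the change here also enlarges the same side of the molecule, though at the amide-type nitrogen rather than on a chain carbon. A downward step of similar or smaller size is therefore expected, a number 0.10 lower from compound 1 to compound 4 (within the scatter), with wide uncertainty. Compound 4 is estimated at 0.22, in the range 0.08 to 0.38.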

Compound 4, intrinsic activity: the largest response reached, as a fraction of the reference agonist's: 0.25
The estimate for compound 4 lay 0.030 below the measured number, within the range that was stated.
By their numbers in this assay, from the lowest: compound 3; then compounds 4 and 1 (each within the scatter of the next).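

In this assay, 1-(furan-2-yl)ethyl in place of propyl on the amide-type nitrogen gives a number 0.070 lower from compound 1 to compound 4 (within the scatter) and so shows that this position can carry a five-membered aromatic ring and a hydrogen-bond acceptor without a step beyond the scatter. The earlier step a number 0.18 lower from compound 1 to compound 3 (beyond the scatter) was a change on a chain carbon and did not test this nitrogen. No measurement at hand gives a cause for this result. As far as these compounds go, whether a thiophene ring or a longer chain such as hexyl on the same nitrogen would give a similar maximal response remains open.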